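A few compounds are considered here, and "the series" means these few. Any claim that something is new, unique, unknown or untested is made for them only; others in the source may bear on it.

Compound 1 `C=CC(=O)c1ccc(CCC)cc1`: > 100000 nM
Compound 2 `CCCCCCc1ccc(NC(=O)C=C(C)C)cc1`: > 100000 nM
Compound 3 `C#CC(=O)Nc1ccc(CCCCCC)cc1`: 68900 nM

Of the compounds shown here, three have been tested in an assay on isolated protein for displacement of a labelled ligand from thyroid hormone receptor alpha (Homo sapiens), read by fluorescence polarization; on this read-out lower numbers stand for stronger inhibition and higher numbers for weaker inhibition. Compound 1 gives > 100000 nM, which is a limit of the assay and not a number. Compound 2 likewise gives > 100000 nM, again a limit. For the measured compounds named here, compound 3 gives 68900 nM, the only true number among the three. The values of compound 1 and compound 2 stop at a limit. Going by the values given here, the one step between close neighbours is an at least 1.4-fold lower number from compound 2 to compound 3 (0.16 log units; that floor lies within the scatter), and its floor lies within the usual scatter, so it shows no clear change.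

Compound 4 `CCCCCCc1ccc(C(=O)C2CO2)cc1` differs from compound 3 by (oxiran-2-yl)carbonyl in place of (ethynylcarbonyl)amino on an aromatic carbon. Among the compounds with values here, no measured step touches this part of the molecule: the only measured step swapped the group on the carbonyl carbon while the amide link stayed in place. What is known is that two of the three values sit at the limit of > 100000 nM in this assay, at which 2 of the 3 values shown sit. Weak binding for compound 4 near that limit is therefore expected, and the expected step is a 1.0-fold higher number from compound 3 to compound 4 (0.01 log units; within the scatter). The estimate for compound 4 is 70000 nM, expected to fall between 15000 nM and 300000 nM.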

Compound 4, half-maximal inhibitory concentration: 33200 nM
Compound 4: middle estimate off by 2.1-fold (0.32 log units), on the high side, and the stated range covers the measured number.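

The change on this aromatic carbon, with (oxiran-2-yl)carbonyl in place of (ethynylcarbonyl)amino, gives a 2.1-fold lower number from compound 3 to compound 4 (0.32 log units; beyond the scatter) in this assay. For the compounds shown here, this is the first step in the set that clearly lies beyond the scatter, so this position can shift the number, although the step is modest. The entering group has no hydrogen-bond donor, yet compound 4 still gives a true number, which not every compound in the set does: the limit of > 100000 nM in this assay, at which 2 of the 4 values shown sit.

The swap alters the link to the ring and the group at its end together, so the compounds shown cannot say which of the two carries the step. Also open, on these data alone, is what an amine or a carboxylic acid on this aromatic carbon would give, and whether a longer chain in the para group would move the number.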